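Compound 3: 3-bromophenyl in place of 4-hydroxyphenyl

The source may hold more compounds than are shown below. What is called first, only, known or untested is meant among the compounds shown, and "the series" means these compounds.

Compound 1 (`CC1(C)[C@H]2CC[C@]1(C)N(Cc1cn(-c3ccccc3Br)nn1)C(=O)C2`) gives 500 nM in a functional assay on SGC-7901 cells (Homo sapiens) for inhibition, read by MTT assay, with a stated time of 24 h; a lower number here means a stronger inhibitor, a higher number a weaker inhibitor
Compound 2 (`CC1(C)[C@H]2CC[C@]1(C)N(Cc1cn(-c3ccc(O)cc3)nn1)C(=O)C2`) gives 330 nM in this assay

Within the data shown here, the numbers do not separate compound 2 from compound 1, as the only measured step is a 1.5-fold lower number from compound 1 to compound 2 (0.18 log units; within the scatter) and nothing more. Compound 3 (`CC1(C)[C@H]2CC[C@]1(C)N(Cc1cn(-c3cccc(Br)c3)nn1)C(=O)C2`) keeps the shared core and carries 3-bromophenyl in place of 4-hydroxyphenyl on an aromatic nitrogen. Among the measured compounds shown here, the one step that bears on this change is the step above, in which 4-hydroxyphenyl replaced 2-bromophenyl at that same place. For the measured compounds named here, no measured compound yet carries 3-bromophenyl, so its own contribution is unknown. Going by the values given here, compound 1, the only measured bromophenyl example, stands at 500 nM and gives no reason to expect a large move. The expected change is a 1.3-fold higher number from compound 2 to compound 3 (0.11 log units; within the scatter) and is estimated to stay within the scatter. For compound 3 the estimated value is 430 nM in this assay (expected range 170 nM to 1100 nM).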

Compound 3, half-maximal inhibitory concentration: 120 nM
The estimate for compound 3 lay 3.6-fold (0.55 log units) above the measured number; measured number below the stated range.
By their numbers in this assay, from the lowest: compound 3; then compounds 2 and 1 (each within the scatter of the next).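

At this place on the aromatic nitrogen, a change of group now gives a step beyond the scatter, which the earlier pair did not: in this assay the change to 3-bromophenyl gives a 2.8-fold lower number from compound 2 to compound 3 (0.44 log units; beyond the scatter). The bromophenyl groups are also separated from each other, with 3-bromophenyl in place of 2-bromophenyl giving a 4.2-fold lower number from compound 1 to compound 3 (0.62 log units; beyond the scatter), so where the bromine stands on the phenyl ring matters here. Of the three compounds, compound 3 has the lowest number, with both of its steps beyond the scatter. No measurement presented here explains these differences.

From the compounds shown here alone, whether 4-bromophenyl would stand with compound 3 or with compound 1 remains open. Also open, going by these compounds, is whether bromine itself is needed, or whether 3-chlorophenyl, 3-methoxyphenyl, 3-aminophenyl or 3-carboxyphenyl would keep the number of compound 3.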